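A few compounds are considered here, and "the series" means these few. Any claim that something is new, unique, unknown or untested is made for them only; others in the source may bear on it.

Working notes on the dihydropyridine ester series.

Two compounds carry numbers in a functional assay on HEK293 cells for antagonist activity at Voltage-dependent L-type calcium channel subunit alpha-1C (Oryctolagus cuniculus), read by FLIPR; on this read-out lower numbers stand for stronger inhibition and higher numbers for weaker inhibition. Compound 1 `COC(=O)C1=C(C)NC(C)=C(C(=O)OCc2ccc(OC)c(OC)c2)C1c1cccc([N+](=O)[O-])c1` gives 112 nM. For the measured compounds named here, compound 2 `COC(=O)C1=C(C)NC(C)=C(C(=O)OCCCCc2ccccc2)C1c1cccc([N+](=O)[O-])c1` gives 10 nM, the lower of the two numbers; the only step available is an 11-fold lower number from compound 1 to compound 2 (1.05 log units; beyond the scatter), so compound 2 stands apart from compound 1 by a margin well beyond the scatter.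

Compound 3 `COC(=O)C1=C(C)NC(C)=C(C(=O)OCCCOc2ccccc2)C1c1cccc([N+](=O)[O-])c1` has not been measured. Against compound 2 the change is phenoxy in place of benzyl on a saturated chain carbon, three bonds along the chain from an oxygen next to a carbonyl group: the chain keeps its length, and the change is limited to exchanging one carbon of the tether for an oxygen, so that 4-phenylbutyl reads as 3-phenoxypropyl.

Going by the values given here, only one step bears on this region, the large step from compound 1 to compound 2, and it swaps a different group, a substituted ring for a longer chain, so it gives no direct guide for a carbon-to-oxygen exchange within a chain of the same length. Without a closer precedent the expected step is small, and in this assay compound 3 is expected near 15 nM, within 5 nM to 50 nM, an estimated 1.5-fold higher number from compound 2 to compound 3 (0.18 log units; within the scatter) from compound 2.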

Compound 3, half-maximal inhibitory concentration: 9 nM
Compound 3: middle estimate off by 1.7-fold (0.22 log units), on the high side; measured number inside the range.
By their numbers in this assay, from the lowest: compounds 3 and 2 (each within the scatter of the next); then compound 1.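

In this assay the exchange of benzyl for phenoxy, on a saturated chain carbon, three bonds along the chain from an oxygen next to a carbonyl group, gives a 1.1-fold lower number from compound 2 to compound 3 (0.05 log units; within the scatter) and so lies within the scatter; at this place in the ester chain, 4-phenylbutyl and 3-phenoxypropyl cannot be told apart, even though the entering group adds a hydrogen-bond acceptor. The further step a 12-fold lower number from compound 1 to compound 3 (1.09 log units; beyond the scatter) is large, as is the step of an 11-fold lower number from compound 1 to compound 2 (1.05 log units; beyond the scatter) printed earlier, so compound 1 now stands apart from two chain esters rather than one. Nothing measured here accounts for the result, and the data give no reason for this near-identity between compound 2 and compound 3.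

The compounds shown leave open whether other atoms in the same tether place, such as a sulfur or an amine nitrogen, would read the same way, and whether the equivalence of the carbon and oxygen tethers would hold in a shorter or longer chain. They also leave open how a substituent on the phenyl ring, such as a fluorine or a methoxy group, would act on the 3-phenoxypropyl ester.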